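The source may hold more compounds than are shown below. What is called first, only, known or untested is meant among the compounds shown, and "the series" means these compounds.

The measured compounds:
compound 1 `CN(C)c1ccc(/C=C2\CCc3cc(O)ccc3C2=O)cc1`: 50000 nM
compound 2 `CN(C)c1ccc(CC2CCc3cc(O)ccc3C2=O)cc1`: 25000 nM
compound 3 `O=C1/C(=C/c2ccc(-c3ccccc3)cc2)CCc2cc(O)ccc21`: 50000 nM

All three were tested in an ADME assay on MCF7 cells for inhibition of cytochrome P450 26A1 (Homo sapiens); on this read-out lower numbers stand for stronger inhibition and higher numbers for weaker inhibition. In this assay compound 1 gives 50000 nM, compound 2 gives 25000 nM and compound 3 gives 50000 nM. Compound 2 has the lowest of the three numbers, but its gaps to compound 1 and to compound 3 both lie within the scatter, so no order among the three can be read from them.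

Compound 3 arises from compound 1 by one change: phenyl in place of dimethylamino on an aromatic carbon. This step gave no change at the digits printed from compound 1 to compound 3 (within the scatter). The same change, made on compound 2, leads to compound 4 `O=C1c2ccc(O)cc2CCC1Cc1ccc(-c2ccccc2)cc1`: phenyl in place of dimethylamino on an aromatic carbon. How the core of compound 2 differs from the core of compound 1 is not broken down here.

Because the change left the number unchanged in no change at the digits printed from compound 1 to compound 3 (within the scatter), the same change is expected to leave compound 2 about where it is, an expected step of no change at the digits printed from compound 2 to compound 4 (within the scatter). Compound 4 is therefore estimated at 25000 nM, most likely between 10000 nM and 60000 nM.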

Compound 4, half-maximal inhibitory concentration: 10000 nM
Compound 4: middle estimate off by 2.5-fold (0.40 log units), on the high side, and the stated range covers the measured number.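

In this assay, putting phenyl in place of dimethylamino on an aromatic carbon gave a 2.5-fold lower number from compound 2 to compound 4 (0.40 log units; beyond the scatter), a modest step that is the clearest movement among the compounds shown. Set beside the earlier step, this one cannot be told apart from it, so the two cores give no sign of responding differently to the change: the same change on two cores in this assay, no change at the digits printed (within the scatter) from compound 1 to compound 3 and a 2.5-fold lower number (0.40 log units; beyond the scatter) from compound 2 to compound 4, 2.5-fold (0.40 log units) apart, within the scatter of two such steps
This shows only that the two results agree within the noise of the measurements; it does not show that the change acts identically on both cores, and two pairs cannot establish a rule for the series or explain the result.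

The compounds shown leave open whether the same swap would give a similar result on a third core. They also leave open how other groups on this aromatic carbon, such as a carboxylic acid, a chlorine atom or a longer carbon chain, would compare with phenyl and dimethylamino.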